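The compounds below may be only part of what the source reports. "The series", "measured", "known", "first", "only" and "open" are said of these compounds alone.

Of the compounds shown here, three that share one core have been tested in a functional assay on MDA-MB-231 cells (Homo sapiens) for cytotoxicity, read by MTT assay, with a stated time of 72 h; a higher number here means a weaker inhibitor, a lower number a stronger inhibitor. Compound 3 `CN(C)CCCCn1c2c(c3ccccc31)C(=O)c1c[n+]([O-])c3ccccc3c1C2=O` gives 350 nM, the lowest of the three numbers. Compound 2 `O=C1c2c[n+]([O-])c3ccccc3c2C(=O)c2c1c1ccccc1n2CCCCN1CCCCC1` gives 610 nM, and the step of a 1.7-fold lower number from compound 2 to compound 3 (0.24 log units; within the scatter) lies within the scatter. Compound 1 `O=C1c2c[n+]([O-])c3ccccc3c2C(=O)c2c1c1ccccc1n2Cc1cn([C@H]2O[C@H](CO)[C@@H](O)[C@H]2O)nn1` gives 1700 nM, a gap to compound 3 that lies beyond the scatter.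

Compound 4 `O=C1c2c[n+]([O-])c3ccccc3c2C(=O)c2c1c1ccccc1n2Cc1cn(C[C@H](O)CO)nn1` is not yet measured. It differs from compound 3 in one place: 1-(2,3-dihydroxypropyl)-1H-1,2,3-triazol-4-yl in place of 3-(dimethylamino)propyl on a saturated chain carbon bound to an aromatic nitrogen. Among the measured compounds shown here, no measured step matches this change; the one measured step only swapped one amine for another and stayed within the scatter. For the measured compounds named here, compound 1, which also carries a triazole rather than an amine chain, gives the weakest number so far because of its 1700 nM.

Compound 4 is therefore expected to give about 1200 nM, between 400 nM and 3500 nM. The expected step is a 3.4-fold higher number from compound 3 to compound 4 (0.54 log units; beyond the scatter).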

Compound 4, half-maximal inhibitory concentration: 1310 nM
The estimate for compound 4 lay 1.1-fold (0.04 log units) below the measured number, within the range that was stated.
By their numbers in this assay, from the lowest: compounds 3 and 2 (each within the scatter of the next); then compounds 4 and 1 (each within the scatter of the next).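

The triazole bearing 2,3-dihydroxypropyl gives a higher number than either amine chain at this position: a 3.7-fold higher number from compound 3 to compound 4 (0.57 log units; beyond the scatter) and a 2.1-fold higher number from compound 2 to compound 4 (0.33 log units; beyond the scatter). Among the triazoles, 2,3-dihydroxypropyl in place of 3,4-dihydroxy-5-(hydroxymethyl)oxolan-2-yl gives no separation, with a 1.3-fold lower number from compound 1 to compound 4 (0.11 log units; within the scatter). Nothing measured here gives a reason for these steps. On these data alone, it stays open whether the higher numbers go with the triazole ring itself or with the missing amine; a triazole carrying a dimethylamino group on its chain would help to separate the two.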